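This account rests on a few compounds, and the source may have more. Where it says the series, first, only, none or still open, it means among the compounds named here.

Compound 1, `CCCc1nc(C)nc2c1CCC(=O)N2Cc1ccc(-c2ccccc2-c2nn[nH]n2)cc1`: -86%
Compound 2, `Cc1nc2c(c(C(F)(F)F)n1)CCC(=O)N2Cc1ccc(-c2ccccc2-c2nn[nH]n2)cc1`: -68%
Compound 3, `CCc1nc(C)nc2c1CCC(=O)N2Cc1ccc(-c2ccccc2-c2nn[nH]n2)cc1`: -104%

Three compounds built on a shared core were measured in a functional assay on the whole organism (artery) with Rattus norvegicus as the target, with a stated time of 60 min, at a dose of 3 mg/kg by the intraduodenal route; a higher number here means more inhibition at the dose given (going by the name of the read-out), a lower number less inhibition. Compound 3 stands lowest of the three. Its nearest neighbour is compound 1, and a number 18 percentage points lower from compound 1 to compound 3 (beyond the scatter). Compound 2 lies furthest away, and a number 36 percentage points lower from compound 2 to compound 3 (beyond the scatter). The remaining comparison between the two higher compounds is a number 18 percentage points higher from compound 1 to compound 2 (beyond the scatter).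

Compound 4, `Cc1nc(C(C)C)c2c(n1)N(Cc1ccc(-c3ccccc3-c3nn[nH]n3)cc1)C(=O)CC2`, has not yet been measured in this assay. It differs from compound 3 in a single place: methyl in place of hydrogen on a saturated chain carbon bound to an aromatic carbon and a saturated chain carbon. Read one bond further out, the same change is ethyl to isopropyl.

The step that speaks most directly to this change is a number 18 percentage points lower from compound 1 to compound 3 (beyond the scatter), which also concerns a methyl group on a saturated chain carbon, but in the opposite direction, where a methyl left and the number fell by a modest amount. The step of a number 36 percentage points lower from compound 2 to compound 3 (beyond the scatter) involves a trifluoromethyl and bears less directly. On this basis a modest rise is expected for compound 4, about a number 16 percentage points higher from compound 3 to compound 4 (beyond the scatter) in this assay. Compound 4 is therefore estimated at -88%, with a range from -115% to -62%.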

Compound 4, a percentage reported as inhibition, in the whole organism at one dose (the size of the read-out at that dose, not a potency) in the Rattus norvegicus assay: -44%
Compound 4: the middle estimate sits 44 percentage points below what was measured; the whole stated range lies below it.
By their numbers in the Rattus norvegicus assay, from the lowest: compound 3; then compound 1; then compound 2; then compound 4.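

In the Rattus norvegicus assay, one methyl added at this carbon, turning ethyl into isopropyl, gives a number 60 percentage points higher from compound 3 to compound 4 (beyond the scatter), whereas a methyl two bonds along the chain from an aromatic carbon had accounted for only a number 18 percentage points lower from compound 1 to compound 3 (beyond the scatter), so the place of the added methyl on the chain matters a great deal. Among these compounds, also in the Rattus norvegicus assay, the branched isopropyl parts clearly from the unbranched propyl, with a number 42 percentage points higher from compound 1 to compound 4 (beyond the scatter), and isopropyl in place of trifluoromethyl gives a number 24 percentage points higher from compound 2 to compound 4 (beyond the scatter), which puts compound 4 at the top of the series rather than inside the range of the earlier compounds. In a physicochemical assay for lipophilicity (a higher number here means a more lipophilic compound, a lower number a more polar compound), compound 3 gives 3.92 and compound 4 gives 4.32, so the partition coefficient moves with the same change, although a single pair cannot tell whether that shift has anything to do with the large step.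

Going by these compounds, whether the trend continues with a bulkier group at this carbon, such as tert-butyl or cyclopropyl, remains open. So does the question of whether an oxygen-bearing chain such as methoxymethyl would behave like isopropyl or like ethyl.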